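Adding a third methoxy group: note on compound 4

The source may report more compounds than this note shows. Statements on the series, on what has been measured and on what is new or still open speak of the compounds shown alone.

Compound 1 `COc1ccc(CS(=O)(=O)/C=C/c2ccc(F)cc2OC)cc1` gives 15000 nM in a functional assay on BT-20 cells (Homo sapiens) for antiproliferative activity, read by trypan blue exclusion; on this read-out lower numbers stand for stronger inhibition and higher numbers for weaker inhibition.
Compound 2 `COc1ccc(CS(=O)(=O)/C=C/c2ccc(OC)c(OC)c2)cc1` gives > 20000 nM in this assay, a limit of the assay and not a number.
Compound 3 `COc1ccc(CS(=O)(=O)/C=C/c2ccc(OC)cc2OC)cc1` gives > 20000 nM in this assay, again a limit of the assay and not a number.

Among the compounds with values here, compound 3 therefore stands at the top end of what this assay reports; compound 1 is the only member of the series with a number, and two of the three values sit at the limit of > 20000 nM in this assay, at which 2 of the 3 values shown sit.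

Compound 4 `COc1ccc(CS(=O)(=O)/C=C/c2ccc(OC)c(OC)c2OC)cc1` differs from compound 3 by methoxy in place of hydrogen on an aromatic carbon. Within the data shown here, the single measured step, an at least 1.3-fold higher number from compound 1 to compound 3 (0.12 log units; that floor lies within the scatter), ends at the limit, so its size is known only as a floor. Among the measured compounds shown here, no measured step puts a methoxy group in place of hydrogen, so the change to compound 4 has no direct precedent here.

With compound 3 already at the limit and compound 2 there as well, compound 4 is expected to stay in the same region, and the step that the limit leaves unreadable from compound 3 to compound 4 is expected to be none beyond the scatter. Compound 4 is thus estimated at 25000 nM, within 10000 nM to 60000 nM, most likely reported again as a limit.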

Compound 4, half-maximal inhibitory concentration: > 20000 nM
Compound 4: no number, only a limit; the forecaster's own chance of this, stated with the estimate: 70%; the middle value lies beyond the limit too.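

The steps from compound 2 and from compound 3 to compound 4 cannot be read, since all three compounds sit at a limit of the assay and not at a number: the limit of > 20000 nM in this assay, at which 3 of the 4 values shown sit.

The compounds shown leave open how methoxy in place of hydrogen on an aromatic carbon acts in this assay on the shared core.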